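A few compounds are considered here, and "the series" means these few. Any claim that something is new, unique, unknown or untested is made for them only; others in the source may bear on it.

Measured in an ADME assay on A549 cells (Homo sapiens) for cytotoxicity, read by MTT assay, with a stated time of 48 h; on this read-out lower numbers stand for stronger inhibition of growth and higher numbers for weaker inhibition of growth:

- compound 1 `O=C(/C=C\c1cccc([N+](=O)[O-])c1)N1N=C(c2ccncc2)OC1c1c[nH]c2ccccc12`: a limit, > 30 ug/mL
- compound 2 `COc1ccc(/C=C\C(=O)N2N=C(c3ccncc3)OC2c2c[nH]c3ccccc23)cc1`: a limit, > 30 ug/mL
- compound 3 `O=C(/C=C\c1cccc(Br)c1)N1N=C(c2ccncc2)OC1c1c[nH]c2ccccc12`: a limit, > 30 ug/mL

Compound 2 stands only at a limit of this assay, not at a number. The same holds for the other two compounds: the limit of > 30 ug/mL in this assay, at which 3 of the 3 values shown sit. The steps among the three are therefore not readable: a step that the two limits leave unreadable from compound 1 to compound 2, a step that the two limits leave unreadable from compound 1 to compound 3, and a step that the two limits leave unreadable from compound 2 to compound 3.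

Compound 4 `O=C(/C=C\c1ccc(Br)cc1)N1N=C(c2ccncc2)OC1c1c[nH]c2ccccc12` has not been measured in this assay. It differs from compound 2 by bromo in place of methoxy on an aromatic carbon. The closest measured change, bromo in place of nitro on an aromatic carbon from compound 1 to compound 3, gave only two limits and says nothing about size or direction.

With all three measured values sitting at the limit, compound 4 is expected to sit there too, and its step that the limit leaves unreadable from compound 2 to compound 4 is estimated to lie within the scatter. Compound 4 is estimated at 45 ug/mL, with a range from 25 ug/mL to 100 ug/mL, and most likely reported only as a limit.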

Compound 4, concentration for 50% growth inhibition: > 30 ug/mL
Compound 4: only a limit was reported; the forecaster's own chance of this, stated with the estimate: 80%; the middle value is on the limit's open side.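

Compound 4 sits at the same limit as compound 1, compound 2 and compound 3, so no new step can be read from it: the limit of > 30 ug/mL in this assay, at which 4 of the 4 values shown sit.

The compounds shown leave open whether any of these changes on the phenyl group alters growth inhibition, as none of them gives a number.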